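A few compounds are considered here, and "the series" means these few. Any claim that something is new, unique, unknown or untested is made for them only; others in the source may bear on it.

Measured compounds and their values:

Compound 1, `CC(C)=CCC/C(C)=C/CC/C(C)=C/CSC[C@H](NC(=O)CCCCCN1CCN(C)CC1)C(=O)NC1CC1`: in a physicochemical assay for lipophilicity (on this read-out lower numbers stand for lower lipophilicity and higher numbers for higher lipophilicity), compound 1 gives 3.66.
Compound 2, `CC(C)=CCC/C(C)=C/CC/C(C)=C/CSC[C@H](NC(=O)CCCCCN1CCCC1)C(=O)NC1CCCCC1`: in this assay compound 2 gives 4.48.
Compound 3, `CC(C)=CCC/C(C)=C/CC/C(C)=C/CSC[C@H](NC(=O)CCCCCN1CCCC1)C(=O)NC1CC1`: in this assay compound 3 gives 3.15.

Compound 2 stands highest of the three numbers in this assay; its nearest neighbour is compound 1, and compound 3 lies furthest from it, with a number 1.33 log units lower from compound 2 to compound 3 (beyond the scatter).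

Compound 4, `CC(C)=CCC/C(C)=C/CC/C(C)=C/CSC[C@H](NC(=O)CCCCCN1CCCC1)C(=O)N1CCCC1`, has not yet been measured. It differs from compound 2 at the amide end of the shared core: pyrrolidin-1-yl in place of cyclohexylamino on a carbonyl carbon. The change most closely related to this one is the step in which cyclohexyl was swapped for cyclopropyl on the same amide-type nitrogen, which gave a number 1.33 log units lower from compound 2 to compound 3 (beyond the scatter). The other measured step, a number 0.51 log units lower from compound 1 to compound 3 (beyond the scatter), concerns the chain end of the molecule and bears on this question only indirectly. Since the entering pyrrolidin-1-yl is also a smaller ring than the leaving cyclohexylamino, a step downward from compound 2 that is beyond the scatter but less than the full cyclohexyl-to-cyclopropyl step seems most likely.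

For compound 4 the expected value in this assay is therefore 3.7, estimated to fall between 3.2 and 4.2. This estimate means a step of a number 0.78 log units lower from compound 2 to compound 4 (beyond the scatter) is expected.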

Compound 4, distribution coefficient: 3.31
Compound 4: middle estimate off by 0.39 log units, on the high side; the measured number falls inside the stated range.
By their numbers in this assay, from the lowest: compounds 3 and 4 (each within the scatter of the next); then compound 1; then compound 2.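

In this assay, putting pyrrolidin-1-yl in place of cyclohexylamino on the carbonyl carbon gives a number 1.17 log units lower from compound 2 to compound 4 (beyond the scatter) and shows that a large fall at this position can occur with a group that has no hydrogen-bond donor, as well as with cyclopropylamino, which keeps one. Within the data shown here, every earlier compound carried a hydrogen-bond donor on this amide-type nitrogen, so this is the first view of a group without one, and the direct comparison gives a number 0.16 log units higher from compound 3 to compound 4 (within the scatter) and leaves cyclopropylamino and pyrrolidin-1-yl indistinguishable on this read-out. In this pair, then, the absence of the donor brings no shift that rises above the scatter, although the ring changes at the same time and the two changes cannot be separated.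

Piperidin-1-yl on the same carbonyl carbon would set a six-membered ring without the donor against cyclohexylamino, and cyclopentylamino would fill the gap among the groups that keep it, so whether the fall follows ring size remains open. Nothing available here explains the size of these steps.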